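This account rests on a few compounds, and the source may have more. Where it says the series, first, only, none or still open, it means among the compounds named here.

Of the compounds shown here, three sharing one core have been measured in a functional assay on HCT-116 cells (Homo sapiens) for inhibition, read by CCK-8 assay, with a stated time of 72 h, tested at 20 uM; a higher number here means more inhibition of growth at the concentration tested, a lower number less inhibition of growth. Compound 1 `CC(C)(C)OC(=O)/C=C1/C(=O)Nc2ccccc21` gives 89.5%, compound 2 `CCCCc1ccc2c(c1)/C(=C\C(=O)OC(C)(C)C)C(=O)N2` gives 89%, and compound 3 `CC(C)(C)OC(=O)/C=C1/C(=O)Nc2ccc(OC(F)(F)F)cc21` gives 87.7%, the lowest of the three numbers, though all three lie within the scatter of one another. Compound 4 `CC(C)(C)OC(=O)/C=C1/C(=O)Nc2ccc([N+](=O)[O-])cc21` differs from compound 3 by nitro in place of trifluoromethoxy on an aromatic carbon. For the measured compounds named here, the steps that bear on this change are substitutions at the same aromatic carbon: a number 0.5 percentage points lower from compound 1 to compound 2 (within the scatter), a number 1.8 percentage points lower from compound 1 to compound 3 (within the scatter) and a number 1.3 percentage points lower from compound 2 to compound 3 (within the scatter), none of them beyond the scatter. Because a number 1.8 percentage points lower from compound 1 to compound 3 (within the scatter) and a number 1.3 percentage points lower from compound 2 to compound 3 (within the scatter) both stayed within the scatter, compound 4 is expected to show no step beyond the scatter in this assay either, a number 0.3 percentage points higher from compound 3 to compound 4 (within the scatter). Compound 4 is therefore estimated at 88%, with a range from 78% to 95%.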

Compound 4, percent growth inhibition at one concentration: 88.1%
Beside the measured number, compound 4's estimate is 0.1 percentage points below it, within the range that was stated.
By their numbers in this assay, from the lowest: compounds 3, 4, 2 and 1 (each within the scatter of the next).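

In this assay nitro is a fourth group on this aromatic carbon, and the steps of a number 0.4 percentage points higher from compound 3 to compound 4 (within the scatter) and a number 0.9 percentage points lower from compound 2 to compound 4 (within the scatter) and a number 1.4 percentage points lower from compound 1 to compound 4 (within the scatter) all stay inside the usual scatter. Hydrogen, butyl, trifluoromethoxy and nitro at this one carbon therefore cannot be told apart at the single concentration tested. Nothing measured here offers a reason for this sameness. On these data alone, whether an amine or a carboxylic acid on this carbon would give a number outside the scatter stays open. So does whether these four compounds would separate at a lower concentration.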